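Swapping an Ester Arm for Dimethylamino: Solubility Outlook

The source may report more compounds than this note shows. Statements on the series, on what has been measured and on what is new or still open speak of the compounds shown alone.

Compound 2, `CCOC(=O)CNc1nc(NC(C)C)nc2ccccc12`, is one of three compounds sharing a core that were tested in a physicochemical assay for solubility, at pH 7.4; a higher number here means a more soluble compound, a lower number a less soluble compound. In this assay compound 2 gives <= 20000 nM, which is a limit of the assay. Compound 1, `OCCNc1nc(NCc2ccco2)c2ccccc2n1`, gives <= 20000 nM in this assay, again a limit. Compound 3, `CC(C)Nc1nc(NC2CCCCC2)c2ccccc2n1`, gives <= 20000 nM in this assay, also a limit. Within the data shown here, the single one-place change among the measured compounds, a step that the two limits leave unreadable from compound 2 to compound 3, therefore cannot be read in size or direction. What the three have in common is the limit of <= 20000 nM in this assay, at which 3 of the 3 values shown sit.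

Compound 4, `CC(C)Nc1nc(N(C)C)c2ccccc2n1`, has not yet been measured in this assay. It differs from compound 2 in one place: dimethylamino in place of ((ethoxycarbonyl)methyl)amino on an aromatic carbon. Among the measured compounds shown here, no measured step bears directly on this change, and the one step that comes closest, from compound 2 to compound 3, is unreadable because both of its ends are limits. For the measured compounds named here, the only guide is that every measured compound sits at the same limit, so the step that the limit leaves unreadable from compound 2 to compound 4 is expected to be too small to separate compound 4 from its neighbours, with no clear direction. Compound 4 is therefore expected to give 12000 nM, with a range from 2000 nM to 20000 nM, and most likely to come back as a limit once more.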

Compound 4, solubility: <= 10000 nM
Compound 4 ended at the assay's limit; the forecaster's own chance of this, stated with the estimate: 70%; at least 1.2-fold (0.07 log units) between middle value and limit.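

In this assay compound 4 gives <= 10000 nM, which is a limit of the assay. Compound 2 and compound 3 also stand at limits, and neither step to compound 4 can be read in size or direction. The compounds shown leave open the true solubility of all four and whether dimethylamino in place of ((ethoxycarbonyl)methyl)amino changes it at all.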